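The source may report more compounds than this note shows. Statements on the series, on what has been measured and on what is new or still open speak of the compounds shown alone.

Series notes, thiazolidinone-free wording: the shared core carries an aryl group on the ring nitrogen and a second aryl group on the ring carbon that bears the large substituent. Three compounds have numbers in a functional assay on MG-63 cells (Homo sapiens) for inhibition, read by CCK-8 assay, with a stated time of 72 h, tested at 1 uM; a lower number here means less inhibition, a higher number more inhibition at the concentration tested (going by the name of the read-out). Compound 1 `COc1ccccc1N1C(=O)CSC1c1cc(F)cc(C(=O)O)c1`, with a carboxylic acid on its second aryl group, gives 0%. Compound 3 `O=C(NCCCCc1ccccc1)c1cccc(C2OCC(=O)N2c2cccc(F)c2)c1`, which carries the phenylbutyl amide, gives 66%. Compound 2 `COc1ccc(C)cc1N1C(=O)CSC1c1cccc(C(=O)NCCCCc2ccccc2)c1` gives 92% and stands highest of the three, beyond the scatter of both compound 3 and compound 1.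

Within the data shown here, compound 4 `COc1c(F)cccc1N1C(=O)CSC1c1cccc(C(=O)NCCCCc2ccccc2)c1` keeps the phenylbutyl amide and the shared core of compound 2; the only change is 3-fluoro-2-methoxyphenyl in place of 2-methoxy-5-methylphenyl on an amide-type nitrogen in a ring. Among the measured compounds shown here, no measured pair in the set isolates a change of this kind on the ring nitrogen, so the step has no direct precedent here. Because the amide-bearing compound 2 sits high at 92% and the amide-bearing compound 3 sits high at 66%, compound 4 is expected to remain well inhibited, with a step of a number 12 percentage points lower from compound 2 to compound 4 (beyond the scatter) expected. The estimate for compound 4 in this assay is 80%, in the range 55% to 95%.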

Compound 4, a percentage reported as inhibition, at one concentration (the size of the read-out at that concentration, not a potency): 0%
For compound 4 the middle estimate is 80 percentage points above the measured one, and the stated range ends above it.
By their numbers in this assay, from the lowest: compounds 1 and 4 (each within the scatter of the next); then compound 3; then compound 2.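

In this assay, with the phenylbutyl amide and the shared core held fixed, 3-fluoro-2-methoxyphenyl in place of 2-methoxy-5-methylphenyl on the amide-type nitrogen in a ring gives a number 92 percentage points lower from compound 2 to compound 4 (beyond the scatter), a large step. The phenylbutyl amide alone therefore does not secure inhibition at this concentration, and the aryl group on this nitrogen can decide between high inhibition and none. Nothing available accounts for this loss.

The change removes the methyl and adds the fluoro in one step, and the compounds shown do not separate the two contributions. On these data alone, it also remains open how this position responds to other groups on the aryl ring, such as chloro or trifluoromethyl, with the phenylbutyl amide kept in place.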